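Extending a halogenated anilide into a biaryl nitrile

The compounds below may be only part of what the source reports. "The series", "measured", "known", "first", "only" and "open" are said of these compounds alone.

Measured compounds:
- compound 1, `CCNC(=O)CCc1cccc2c1B(O)OC2`: > 100000 nM
- compound 2, `O=C(CCc1cccc2c1B(O)OC2)Nc1ccc(I)cc1`: 33000 nM
- compound 3, `O=C(CCc1cccc2c1B(O)OC2)Nc1cccc(Br)c1`: 720 nM

Three amides built on a shared boron-containing core have been tested in a functional assay on MDA-MB-231 cells (Homo sapiens) for antiproliferative activity, read by MTT assay, with a stated time of 72 h; on this read-out lower numbers stand for stronger inhibition and higher numbers for weaker inhibition. Compound 1 carries an ethyl group on the amide nitrogen; its value of > 100000 nM is a limit of this assay, not a number. Compound 2 bears a 4-iodophenyl group on that nitrogen and gives 33000 nM. Compound 3 bears a 3-bromophenyl group and gives 720 nM, the lowest of the two actual numbers; the nearest is compound 2, with a 46-fold lower number from compound 2 to compound 3 (1.66 log units; beyond the scatter). Replacing ethyl by an aryl group gave an at least 3.0-fold lower number from compound 1 to compound 2 (0.48 log units; beyond the scatter) and an at least 130-fold lower number from compound 1 to compound 3 (2.14 log units; beyond the scatter).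

Compound 4, `N#Cc1ccc(-c2cccc(NC(=O)CCc3cccc4c3B(O)OC4)c2)cc1`, keeps the anilide of compound 3 but differs by 4-cyanophenyl in place of bromo on an aromatic carbon. Among the compounds with values here, no measured step swaps a halogen for a second aromatic ring, so the only guidance is that changes to the aryl substituent have moved potency by large amounts, as in a 46-fold lower number from compound 2 to compound 3 (1.66 log units; beyond the scatter), in either direction. The number for compound 4 in this assay is therefore expected to lie near that of compound 3, with wide uncertainty: the estimated step is a 2.1-fold higher number from compound 3 to compound 4 (0.32 log units; beyond the scatter). Compound 4 is estimated at 1500 nM, between 250 nM and 9000 nM.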

Compound 4, half-maximal inhibitory concentration: 380 nM
The estimate for compound 4 lay 3.9-fold (0.60 log units) above the measured number; the range from low to high includes it.
By their numbers in this assay, from the lowest: compounds 4 and 3 (each within the scatter of the next); then compound 2. At a limit, above all of these: compound 1.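

In this assay the swap of bromo for 4-cyanophenyl gives a 1.9-fold lower number from compound 3 to compound 4 (0.28 log units; within the scatter) and so the two compounds cannot be told apart. Until now the aryl group on the amide nitrogen had carried only a single halogen atom, whereas here an aromatic carbon meta to a large group takes a substituent of 8 heavy atoms in place of 1, with a second aromatic ring and a nitrile, and the antiproliferative number stays in the same range. A much larger group at this place therefore does not produce a shift like the one in a 46-fold lower number from compound 2 to compound 3 (1.66 log units; beyond the scatter) and the low number seen with compound 3 is not tied to the bromo group.

A phenyl ring without the nitrile, or one with a carboxylic acid or an amine in the nitrile's place, would show whether the added ring alone is enough to keep this level of activity or whether its substituent also counts. No measurement shown here bears on why the larger group leaves the number within the scatter of compound 3.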